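Compound 3 to Compound 4: Methyl to Hydrogen

This account rests on a few compounds, and the source may have more. Where it says the series, first, only, none or still open, it means among the compounds named here.

Compound 3 `Cc1cc(-c2ccccc2)n(/C(N)=N/S(=O)(=O)c2cc(C)c(Cl)cc2SCc2ccc(C(F)(F)F)cc2)n1` is one of three related compounds tested in a functional assay on HeLa cells (Homo sapiens) for cytotoxicity, read by MTT assay, with a stated time of 72 h; on this read-out lower numbers stand for stronger inhibition and higher numbers for weaker inhibition. Compound 3 gives 19000 nM, the highest of the three numbers. Compound 1 `Cc1cccc(CSc2cc(Cl)c(C)cc2S(=O)(=O)/N=C(\N)n2nccc2-c2ccccc2)c1` gives 8000 nM in this assay, and compound 2 `Cc1cc(S(=O)(=O)/N=C(\N)n2nccc2-c2ccccc2)c(SCc2cccc(Cl)c2)cc1Cl` gives 10000 nM. The gap from compound 3 to compound 2 lies within the scatter, while the gap from compound 3 to compound 1 lies beyond it. Among the compounds with values here, the only step measured between direct neighbours, a 1.3-fold higher number from compound 1 to compound 2 (0.10 log units; within the scatter), concerns a different part of the molecule.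

Compound 4 `Cc1cc(S(=O)(=O)/N=C(\N)n2nccc2-c2ccccc2)c(SCc2ccc(C(F)(F)F)cc2)cc1Cl` has not yet been measured. It differs from compound 3 by hydrogen in place of methyl on an aromatic carbon. Within the data shown here, no measured pair shows this kind of change, and the single measured step, a 1.3-fold higher number from compound 1 to compound 2 (0.10 log units; within the scatter), lies within the scatter and sits elsewhere on the molecule. No step beyond the scatter is therefore expected in this assay, in either direction. Compound 4 is expected to give about 15000 nM, within a range from 6000 nM to 40000 nM. The expected step is accordingly a 1.3-fold lower number from compound 3 to compound 4 (0.10 log units; within the scatter).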

Compound 4, half-maximal inhibitory concentration: 17000 nM
Compound 4: the middle estimate sits 1.1-fold (0.05 log units) below what was measured; the range from low to high includes it.
By their numbers in this assay, from the lowest: compounds 1, 2, 4 and 3 (each within the scatter of the next, the first and the last beyond it).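

In this assay, within the data shown here, the first change at this carbon of the five-membered ring, hydrogen in place of methyl, gives a 1.1-fold lower number from compound 3 to compound 4 (0.05 log units; within the scatter) and so shows that the methyl can go without a step beyond the scatter in this read-out. Removing it also makes compound 4 a direct neighbour of compounds 1 and 2 at the aryl group on the sulfur-bound chain carbon: 4-(trifluoromethyl)phenyl gives a 1.7-fold higher number from compound 2 to compound 4 (0.23 log units; within the scatter) against 3-chlorophenyl and a 2.1-fold higher number from compound 1 to compound 4 (0.33 log units; beyond the scatter) against 3-methylphenyl, so only the second step, a modest one, lies beyond the scatter. No measurement shown here offers an explanation for these steps.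

On these data alone, whether an amine or an ethyl group on this same ring carbon would move the number remains open. A single pair also cannot show whether losing the methyl would have the same small effect with a different aryl group on the chain.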